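A few compounds are considered here, and "the series" means these few. Any claim that something is new, unique, unknown or untested is made for them only; others in the source may bear on it.

In a functional assay (Mus musculus) for inhibition, with a stated time of 5 days (a higher number here means a weaker inhibitor, a lower number a stronger inhibitor), two compounds have been measured:

Compound 1 `O=C(O)/C=C/c1cn(-c2ccc(O)cc2)nc1-c1ccc(O)cc1`: > 100000 nM (a limit of the assay)
Compound 2 `O=Cc1cn(-c2ccc(O)cc2)nc1-c1ccc(O)c(O)c1`: 12000 nM

Among the compounds with values here, compound 2 holds the only actual number in this assay, at 12000 nM. Compound 1 is reported only as a limit, > 100000 nM. Within the data shown here, with a single number and a single limit, the series offers no measured step to serve as a guide.

Compound 3 `O=Cc1cn(-c2ccc(O)cc2)nc1-c1ccc(O)cc1` has not yet been measured. It differs from compound 2 by hydrogen in place of hydroxy on an aromatic carbon, ortho to a hydroxy group and meta to a large group.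

Among the measured compounds shown here, no measured pair isolates this change, so the size of the step can only be judged loosely. A moderate weakening is expected in this assay, with the number rising beyond the usual scatter, starting from compound 2 at 12000 nM. The estimated step is a 2.9-fold higher number from compound 2 to compound 3 (0.46 log units; beyond the scatter). For compound 3 the expected value is 35000 nM, with an estimated range of 14000 nM to 100000 nM.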

Compound 3, half-maximal inhibitory concentration: 44000 nM
Estimate against measurement, compound 3: 1.3-fold (0.10 log units) below; the measured number falls inside the stated range.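

In this assay, within the data shown here, the change gives the first measured reading for this position: losing the hydroxy that stands ortho to a hydroxy group and meta to a large group produces a 3.7-fold higher number from compound 2 to compound 3 (0.56 log units; beyond the scatter), so this hydroxy contributes to inhibition in compound 2, although compound 3 still gives a measurable value without it. The new compound also isolates a second change, on a different aromatic carbon, where formyl in place of 2-carboxyethenyl gives an at least 2.2-fold lower number from compound 1 to compound 3 (0.35 log units; beyond the scatter). Compound 1 gives > 100000 nM, which is a limit of the assay and not a number: the limit of > 100000 nM in this assay, at which 1 of the 3 values shown sits.

The compounds shown leave open whether the gain depends on the hydroxy itself, since no methoxy, amine or fluorine at this position can be compared with it. They also leave open whether the same hydroxy would have a step of similar size with a group other than formyl on the shared core, such as a carboxylic acid or a longer chain.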